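Para substituent swaps on a shared imidazole core

The source may report more compounds than this note shows. Statements on the series, on what has been measured and on what is new or still open speak of the compounds shown alone.

Compound 1 `CCC(C)(C)Cc1c[nH]c(CCc2ccc(-c3cccc(C)n3)cc2)n1`: 102 nM
Compound 2 `CCC(C)(C)Cc1c[nH]c(CCc2ccc(-n3cccn3)cc2)n1`: 106 nM
Compound 3 `CCC(C)(C)Cc1c[nH]c(CCc2ccc(-c3cccc(N)n3)cc2)n1`: 97 nM

Three compounds share one core and differ only in the group on the aromatic carbon para to the large group. In a functional assay on HEK293 cells for agonist activity at Bombesin receptor subtype-3 (Homo sapiens), read by luminescence and calcium flux, with a stated time of 10 min (a higher number here means that more compound is needed for the effect, a lower number that less compound is needed), compound 1 gives 102 nM, compound 2 gives 106 nM and compound 3 gives 97 nM. The three numbers sit close together: a 1.0-fold higher number from compound 1 to compound 2 (0.02 log units; within the scatter), a 1.1-fold lower number from compound 1 to compound 3 (0.02 log units; within the scatter) and a 1.1-fold lower number from compound 2 to compound 3 (0.04 log units; within the scatter). Compound 3 therefore stands among its neighbours with no separation that the assay could resolve.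

Compound 4 `CCC(C)(C)Cc1c[nH]c(CCc2ccc(-c3csnn3)cc2)n1` is not yet measured. It differs from compound 3 by 1,2,3-thiadiazol-4-yl in place of 6-aminopyridin-2-yl on an aromatic carbon. Of the measured steps, the closest parallels are the exchange of a six-membered aromatic ring for a five-membered one in a 1.0-fold higher number from compound 1 to compound 2 (0.02 log units; within the scatter) and the reverse in a 1.1-fold lower number from compound 2 to compound 3 (0.04 log units; within the scatter), both of which stayed within the scatter. On that basis compound 4 is expected to show a step of about a 1.1-fold higher number from compound 3 to compound 4 (0.03 log units; within the scatter), that is, no movement beyond the scatter in either direction. The estimate for compound 4 in this assay is 105 nM, with a range from 45 nM to 250 nM.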

Compound 4, half-maximal effective concentration: 104 nM
The estimate for compound 4 lay 1.0-fold (0.00 log units) above the measured number; low and high end bracket the measured number.
By their numbers in this assay, from the lowest: compounds 3, 1, 4 and 2 (each within the scatter of the next).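

In this assay, the exchange of 6-aminopyridin-2-yl for 1,2,3-thiadiazol-4-yl gives a 1.1-fold higher number from compound 3 to compound 4 (0.03 log units; within the scatter), and the new group is equally unresolved from the other two, with a 1.0-fold lower number from compound 2 to compound 4 (0.01 log units; within the scatter) and a 1.0-fold higher number from compound 1 to compound 4 (0.01 log units; within the scatter). For the compounds shown here, this extends what the earlier compounds showed: on this aromatic carbon, para to a large group, the number stays within the scatter even with a five-membered aromatic ring with 3 hetero atoms, one of them sulfur, and with 0 hydrogen-bond donors in place of the 1 carried by the group that leaves. No supporting data bear on why these groups cannot be told apart in this assay.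

As far as these compounds go, all four compounds carry an aromatic ring on this carbon, so it remains open what a carboxylic acid, a simple amine or a longer alkyl chain in that place would do to the number. The rest of the shared core is also the same throughout, which leaves open whether the same lack of separation among these groups would hold on a different core.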